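The compounds below may be only part of what the source reports. "The series", "measured", "known", "first", "only" and "open" are said of these compounds alone.

Compound 2, with the structure `CCSC(=O)C1=C(C)NC(=O)NC1c1ccoc1`, gives in an assay on membranes from CHO cells for displacement of a labelled ligand from adenosine receptor A1 (Homo sapiens), read by scintillation counting, with a stated time of 60 min, tested at 1 uM (on this read-out lower numbers stand for less inhibition and higher numbers for more inhibition at the one concentration tested (going by the name of the read-out)), a value of 3%. Going by the values given here, on the two numbers measured so far this is the lowest; its nearest neighbour, compound 1 with the structure `CC1=C(C(=O)CC(C)C)C(c2ccoc2)NC(=O)N1`, gives in this assay a value of 23%. Among the compounds with values here, the one measured step, a number 20 percentage points lower from compound 1 to compound 2 (beyond the scatter), came from exchanging the group on the carbonyl carbon, and it is the only step that bears on the move now considered. Compound 3, with the structure `CCC(C)OC(=O)C1=C(C)NC(=O)NC1c1ccoc1`, differs from compound 2 in this way: sec-butoxy in place of ethylsulfanyl on a carbonyl carbon. The measured step shows that the group on the carbonyl carbon can shift the read-out by a modest amount, but it runs from isobutyl to ethylsulfanyl and does not cover sec-butoxy, so it offers no direct guide to direction. Since compound 2 already sits near the bottom of the scale, the expected change for compound 3 is small, a number 5 percentage points higher from compound 2 to compound 3 (within the scatter), with no step beyond the scatter expected. Compound 3 is therefore estimated at 8%, within a range from 0% to 25%.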

Compound 3, a percentage reported as inhibition, at one concentration (the size of the read-out at that concentration, not a potency): 13%
The estimate for compound 3 lay 5 percentage points below the measured number; the range from low to high includes it.
By their numbers in this assay, from the lowest: compounds 2, 3 and 1 (each within the scatter of the next, the first and the last beyond it).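

In this assay, putting sec-butoxy on the carbonyl carbon in place of ethylsulfanyl gives a number 10 percentage points higher from compound 2 to compound 3 (within the scatter), and putting it there in place of isobutyl gives a number 10 percentage points lower from compound 1 to compound 3 (within the scatter), so this one group cannot be told apart from either of the earlier two. Going by these compounds alone, the earlier compounds offered only a single step at this position, a number 20 percentage points lower from compound 1 to compound 2 (beyond the scatter), and that step alone could suggest a clear separation between groups; compound 3 now fills the gap, with both of its steps inside the scatter, and so the three groups do not yet resolve into an order that could be tied to the group on the carbonyl carbon, beyond the one difference between compound 1 and compound 2. No measurement at hand accounts for any of these numbers.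

The compounds shown leave open how a carboxylic acid, an amide made from a simple amine, or a longer alkoxy chain on the same carbonyl carbon would read in this assay. They also leave open whether changes elsewhere on the shared core, such as at the ring that carries the substituent common to all three compounds, would move the number further than any exchange at this position has.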